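Antiproliferative series on the shared core: trichlorophenyl variant

A few compounds are considered here, and "the series" means these few. Any claim that something is new, unique, unknown or untested is made for them only; others in the source may bear on it.

Compound 1 `Cc1ccc(-n2nncc2CN2C(=O)C3(C(C#N)=C(N)Oc4c3c3nc5ccccc5nc3c3ccccc43)c3ccccc32)c(C)c1` was tested in a functional assay on A549 cells (Homo sapiens) for antiproliferative activity, read by MTT assay, with a stated time of 48 h (on this read-out lower numbers stand for stronger inhibition and higher numbers for weaker inhibition), and returns only a limit, compound 1 giving > 50000 nM. Compound 2 `CC(=O)Nc1ccc(-n2nncc2CN2C(=O)C3(C(C#N)=C(N)Oc4c(N)cc5nc6ccccc6nc5c43)c3ccccc32)cc1` likewise returns only a limit in this assay, compound 2 giving > 50000 nM. Where compound 2 stands is therefore known only as a limit, and the one other value of the series is a limit as well, both resting on (the limit of > 50000 nM in this assay, at which 2 of the 2 values shown sit). Among the compounds with values here, no pair of measured compounds differs in a single place, so no measured step exists to scale from.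

Compound 3 `N#CC1=C(N)Oc2c(N)cc3nc4ccccc4nc3c2C12C(=O)N(Cc1cnnn1-c1c(Cl)cc(Cl)cc1Cl)c1ccccc12` is the next variant to be measured in this assay. It differs from compound 2 by 2,4,6-trichlorophenyl in place of 4-acetamidophenyl on an aromatic nitrogen.

Within the data shown here, with both measured compounds sitting at the limit, no direction for the step from compound 2 to compound 3 can be read off the series; the expectation is no step beyond the scatter, and the estimated step is a step that the limit leaves unreadable from compound 2 to compound 3. Compound 3 is expected to give about 60000 nM in this assay, with a range from 20000 nM to 200000 nM, most likely again reported as a limit.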

Compound 3, half-maximal inhibitory concentration: > 50000 nM
Compound 3 ended at the assay's limit (the forecaster's own chance of this, stated with the estimate: 80%); the middle value is on the limit's open side.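

No step from compound 2 to compound 3 can be read, because both compounds stand at a limit and not at a number: the limit of > 50000 nM in this assay, at which 3 of the 3 values shown sit.

The compounds shown leave open how any group on the aromatic nitrogen, or any other change to the shared core, would act in this assay once a value falls inside the measurable range.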